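This account rests on a few compounds, and the source may have more. Where it says the series, first, only, none or still open, it means among the compounds named here.

This account follows a small set of compounds sharing one core. Compound 1 `O=c1oc2c(O)c(O)ccc2cc1-c1ccsc1` was tested in a functional assay on isolated protein for antagonist activity at adenosine receptor A2b (Homo sapiens) (on this read-out higher numbers stand for weaker inhibition and lower numbers for stronger inhibition), and gave only a limit of the assay, > 30000 nM. Compound 2 `O=c1oc2c(O)cccc2cc1-c1cc(Br)cs1` was tested in this assay and likewise gave a limit of the assay, > 30000 nM. Both results sit at the same boundary, (the limit of > 30000 nM in this assay, at which 2 of the 2 values shown sit), so compound 2 stands at that limit with no number that would rank it against compound 1. Compound 3 `O=c1oc2c(O)c(O)ccc2cc1-c1cc(Br)cs1` is still to be measured in this assay. Relative to compound 2 the change is hydroxy in place of hydrogen on an aromatic carbon, in words hydroxy in place of hydrogen on an aromatic carbon. Going by the values given here, no measured pair isolates this change, and compound 1, which already carries the second hydroxy, also rests at the limit. The step from compound 2 to compound 3 is therefore expected to be a number no higher from compound 2 to compound 3 (the limit leaves the size open), nothing beyond the scatter. Compound 3 is estimated at 30000 nM, in the range 10000 nM to 100000 nM, most probably reported once more only as a limit.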

Compound 3, inhibition constant: > 30000 nM
Compound 3: a limit, no number; the forecaster's own chance of this, stated with the estimate: 80%; the middle value sits exactly at the limit.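

In this assay compound 3 gives > 30000 nM, again only a limit of the assay. Going by these compounds alone, no step from compound 1 or compound 2 to compound 3 can be read: the limit of > 30000 nM in this assay, at which 3 of the 3 values shown sit. The compounds shown leave open how strongly any of the three inhibits the receptor.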